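Hexylamide of the series: expectation at the assay limit

The source may report more compounds than this note shows. Statements on the series, on what has been measured and on what is new or still open speak of the compounds shown alone.

Within the data shown here, compound 1 `COc1cc(-c2cc(C(=O)O)c3ccccc3n2)ccc1OCC(=O)Nc1cccc(C(F)(F)F)c1` is the only member with a numerical reading: in an ADME assay on HaCaT cells (Homo sapiens) for inhibition (on this read-out lower numbers stand for stronger inhibition and higher numbers for weaker inhibition), compound 1 gives 160000 nM. Compound 2 `COc1cc(-c2cc(C(=O)O)c3ccccc3n2)ccc1OCC(=O)NCc1ccco1` reaches only a limit of this assay, > 300000 nM. Compound 3 `COc1cc(-c2cc(C(=O)O)c3ccccc3n2)ccc1OCC(=O)NCc1cccs1` also stands at a limit of this assay, giving > 300000 nM. The steps of an at least 1.8-fold higher number from compound 1 to compound 2 (0.27 log units; that floor lies within the scatter) and an at least 1.8-fold higher number from compound 1 to compound 3 (0.27 log units; that floor lies within the scatter) have floors that lie within the scatter, and a step that the two limits leave unreadable from compound 2 to compound 3 cannot be sized, since both ends rest on (the limit of > 300000 nM in this assay, at which 2 of the 3 values shown sit).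

Compound 4 `CCCCCCNC(=O)COc1ccc(-c2cc(C(=O)O)c3ccccc3n2)cc1OC` differs from compound 3 by pentyl in place of thiophen-2-yl on a saturated chain carbon bound to an amide-type nitrogen. Among the measured compounds shown here, the steps that bear on the amide substituent are the two from compound 1 and the one between compound 2 and compound 3; none of them produced a readable movement in this assay, and none exchanges a ring for a chain. The step that the limit leaves unreadable from compound 3 to compound 4 is therefore expected to stay within the scatter. Compound 4 is expected to remain at or near the limit, estimated at 350000 nM with a range of 120000 nM to 1000000 nM.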

Compound 4, half-maximal inhibitory concentration in the HaCaT assay: > 300000 nM
Compound 4 ended at the assay's limit; the forecaster's own chance of this, stated with the estimate: 70%; the middle value is on the limit's open side.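

In the HaCaT assay, hexyl in place of 3-(trifluoromethyl)phenyl on an amide-type nitrogen gives an at least 1.8-fold higher number from compound 1 to compound 4 (0.27 log units; that floor lies within the scatter), so this open chain reads no differently from the two rings, and the steps to compound 4 from compound 2 and compound 3 cannot be read. The ring-to-chain change does register in a physicochemical assay for lipophilicity, using the shake flask method, in phosphate buffer, measured as octanol-water partition, at pH 7.4 (on this read-out lower numbers stand for lower lipophilicity and higher numbers for higher lipophilicity), where compound 3 gives 0 and compound 4 gives 1. Lipophilicity rises in the physicochemical assay: the measured distribution coefficient of compound 3, 0, and of compound 4, 1, a number 1.00 log units higher (beyond the scatter) Compound 4 still stands at a limit, not a number, in the HaCaT assay, so the change that moves the value in the physicochemical assay stays unreadable in the HaCaT assay: the limit of > 300000 nM in the HaCaT assay, at which 3 of the 4 values shown sit.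

On these data alone, only compound 1 has a numerical reading in the HaCaT assay, so what separates it from the other amides stays open. Also open, as far as these compounds go, is how a longer chain such as octyl, or a primary amine at the end of the hexyl chain, would read in either assay.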